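The source may report more compounds than this note shows. Statements on the series, on what has been measured and on what is new or still open speak of the compounds shown alone.

Working notes on the series built on the shared core, read in a functional assay on HCT-116 cells (Homo sapiens) for cytotoxicity, read by crystal violet staining and colony formation, with a stated time of 7 days; on this read-out higher numbers stand for weaker inhibition and lower numbers for stronger inhibition. Compound 1 `CC(C)C(=O)Oc1cc(O)c2c(c1)OC(c1ccc(O)cc1)CC2=O` gives 15900 nM, compound 2 `O=C(Oc1ccccc1)Oc1cc(O)c2c(c1)OC(c1ccc(O)cc1)CC2=O` gives 20000 nM, and compound 3 `Cc1ccccc1C(=O)Oc1cc(O)c2c(c1)OC(c1ccc(O)cc1)CC2=O` gives 6030 nM. Compound 3 has the lowest number of the three, and both steps leading to it lie beyond the scatter: a 2.6-fold lower number from compound 1 to compound 3 (0.42 log units; beyond the scatter) and a 3.3-fold lower number from compound 2 to compound 3 (0.52 log units; beyond the scatter). Both are modest. The remaining step, a 1.3-fold higher number from compound 1 to compound 2 (0.10 log units; within the scatter), stays within the scatter.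

Compound 4 `O=C(Oc1cc(O)c2c(c1)OC(c1ccc(O)cc1)CC2=O)c1cccs1` carries the change (thiophen-2-yl in place of 2-methylphenyl on a carbonyl carbon), on a carbonyl carbon. Within the data shown here, no measured step replaces one aromatic ring with another at this place, so the evidence is indirect. The two steps into compound 3 show only how far the numbers have moved with changes on this carbonyl carbon. A small move to a higher number is expected in this assay, probably not beyond the scatter, since compound 3 at 6030 nM is the lowest so far. The expected step is a 1.7-fold higher number from compound 3 to compound 4 (0.22 log units; within the scatter). For compound 4 the estimate is 10000 nM, with an expected range of 4000 nM to 22000 nM.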

Compound 4, half-maximal inhibitory concentration: 1200 nM
Compound 4: middle estimate off by 8.3-fold (0.92 log units), on the high side; the whole stated range lies above it.
By their numbers in this assay, from the lowest: compound 4; then compound 3; then compounds 1 and 2 (each within the scatter of the next).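

In this assay the exchange of one aromatic ring for another on this carbonyl carbon gives a 5.0-fold lower number from compound 3 to compound 4 (0.70 log units; beyond the scatter) and so shows that the identity of the aromatic ring alone can move the number beyond the scatter. Against the phenoxy and isopropyl groups the steps reach a 17-fold lower number from compound 2 to compound 4 (1.22 log units; beyond the scatter) and a 13-fold lower number from compound 1 to compound 4 (1.12 log units; beyond the scatter) and these are the first large steps at this place, where the earlier ones were modest or within the scatter. No measurement at hand accounts for this change.

The step from 2-methylphenyl to thiophen-2-yl alters the ring size, the ring atoms and the methyl group together, and the compounds shown do not separate these. Going by these compounds, how an unsubstituted phenyl, a furan-2-yl or a thiophen-3-yl on this carbonyl carbon would read also remains open.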